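Trimming One Methoxy from a Cell-Growth Inhibitor

The source may hold more compounds than are shown below. What is called first, only, known or untested is meant among the compounds shown, and "the series" means these compounds.

Among the compounds with values here, compound 1 `C=C(Br)C(=O)Nc1cccc(-c2cn3nc(-c4ccc(OC)c(OC)c4)sc3n2)c1` has the lowest number of the two compounds measured so far: in a functional assay on HeLa cells (Homo sapiens) for inhibition, read by cell counting, with a stated time of 4 days (a lower number here means a stronger inhibitor, a higher number a weaker inhibitor), compound 1 gives 610 nM, while compound 2 `Nc1cccc(-c2cn3c(-c4ccc(Cl)cc4)csc3n2)c1` gives 17000 nM, a gap well beyond the usual scatter. Compound 3 `C=C(Br)C(=O)Nc1cccc(-c2cn3nc(-c4ccc(OC)cc4)sc3n2)c1` differs from compound 1 in a single place: hydrogen in place of methoxy on an aromatic carbon. Within the data shown here, no measured pair shows this exact change, so only a modest step in this assay is expected, most likely a slight weakening that may not clear the scatter. The step expected from that change is a 1.5-fold higher number from compound 1 to compound 3 (0.17 log units; within the scatter). Compound 3 is therefore estimated at 900 nM, within a range of 300 nM to 2700 nM.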

Compound 3, half-maximal inhibitory concentration: 2300 nM
Estimate against measurement, compound 3: 2.6-fold (0.41 log units) below, within the range that was stated.
By their numbers in this assay, from the lowest: compound 1; then compound 3; then compound 2.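

Cutting 3,4-dimethoxyphenyl back to 4-methoxyphenyl gives a 3.8-fold higher number from compound 1 to compound 3 (0.58 log units; beyond the scatter) in this assay, so the methoxy that leaves does matter at this position. Within the data shown here, this is the first reading of a single change, as compound 1 and compound 2 differ in more than one place. Nothing measured here explains the loss. The compounds shown leave open how a hydroxyl, an ethoxy or an amine at this place would compare with methoxy, and what the remaining methoxy contributes.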